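The source may report more compounds than this note shows. Statements on the series, on what has been measured and on what is new or still open speak of the compounds shown alone.

Working notes on the series. Among the compounds with values here, in an ADME assay on the whole organism (plasma) for pharmacokinetics, with Rattus norvegicus as the target, with a stated time of 6 h, at a dose of 10 mg/kg by the oral route (on this read-out higher numbers stand for higher exposure at the dose given and lower numbers for lower exposure), compound 1 `CCOCCNc1nc(C)c(-c2nc3ccccc3s2)c(N[C@@H]2C[C@H](CO)[C@@H](O)[C@H]2O)n1` gives 1100 ng.h/mL and compound 2 `Cc1nc(NCCCC(F)(F)F)nc(N[C@@H]2C[C@H](CO)[C@@H](O)[C@H]2O)c1-c1nc2ccccc2s1` gives 1040 ng.h/mL; the two numbers sit within the scatter of each other, as the step of a 1.1-fold lower number from compound 1 to compound 2 (0.02 log units; within the scatter) shows, so compound 2 stands level with the only other measured compound. Compound 3 `Cc1nc(NCc2ccncc2)nc(N[C@@H]2C[C@H](CO)[C@@H](O)[C@H]2O)c1-c1nc2ccccc2s1` carries pyridin-4-yl in place of 3,3,3-trifluoropropyl on a saturated chain carbon bound to a nitrogen on an aromatic ring. Within the data shown here, the one measured step altered a group on the chain and stayed within the scatter; no measured step brings a ring into this position, so there is no basis for expecting a step beyond the scatter in either direction. Compound 3 is therefore estimated at about 650 ng.h/mL, with a range from 200 ng.h/mL to 2000 ng.h/mL, which would correspond to an expected 1.6-fold lower number from compound 2 to compound 3 (0.20 log units; within the scatter).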

Compound 3, area under the concentration-time curve: 47.9 ng.h/mL
Compound 3: the middle estimate sits 14-fold (1.13 log units) above what was measured; measured number outside the range, below it.
By their numbers in this assay, from the lowest: compound 3; then compounds 2 and 1 (each within the scatter of the next).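

Changing what sits on this saturated chain carbon can move exposure strongly: in this assay, pyridin-4-yl gives a 22-fold lower number from compound 2 to compound 3 (1.34 log units; beyond the scatter) and a 23-fold lower number from compound 1 to compound 3 (1.36 log units; beyond the scatter), whereas the two ringless groups of compound 1 and compound 2 stand level. So the earlier step within the scatter does not mean that this position tolerates every change. Nothing on hand explains the loss.

The compounds shown leave open whether it follows the aromatic ring itself or its ring nitrogen; a phenyl group here would separate the two. From the compounds shown here alone, how an amine or a longer chain behaves here also remains open.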